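Imidazole substitution in the diphenyl amide series

The source may report more compounds than this note shows. Statements on the series, on what has been measured and on what is new or still open speak of the compounds shown alone.

In an assay on ileum with muscarinic acetylcholine receptor M3 (Cavia porcellus) as the target (a higher number here means a weaker inhibitor, a lower number a stronger inhibitor), compound 2 `CCc1nccn1CCC(C(N)=O)(c1ccccc1)c1ccccc1` gives 78.1 nM, the lower of the two numbers at hand. Compound 1 `c1ccc(C(CCn2ccnc2)c2ccccc2)cc1` gives 89.1 nM; the two values lie within the scatter, so no order between them is drawn. Compound 3 `Cc1cn(CCC(C(N)=O)(c2ccccc2)c2ccccc2)cn1` carries the change (4-methyl-1H-imidazol-1-yl in place of 2-ethyl-1H-imidazol-1-yl on a saturated chain carbon, three bonds along the chain from two aromatic carbons and a carbonyl carbon). Among the measured compounds shown here, no pair of measured compounds shows this step, so its size is open; the expectation is a shift of a 1.4-fold higher number from compound 2 to compound 3 (0.15 log units; within the scatter) for compound 3, a small move toward a weaker value or none beyond the scatter. Compound 3 is estimated at 110 nM, with a range from 35 nM to 350 nM.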

Compound 3, antagonist equilibrium constant: 10.1 nM
The estimate for compound 3 lay 11-fold (1.04 log units) above the measured number; measured number outside the range, below it.
By their numbers in this assay, from the lowest: compound 3; then compounds 2 and 1 (each within the scatter of the next).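

In this assay, among the compounds shown here, the change to 4-methyl-1H-imidazol-1-yl gives a 7.7-fold lower number from compound 2 to compound 3 (0.89 log units; beyond the scatter) and so makes this the first step that reads beyond the scatter: the substitution on the imidazole matters at this position. The step replaces ethyl with methyl and moves the substituent from the 2 to the 4 position of the ring together, so the two changes remain unseparated. No measured evidence accounts for the size of this step.

Still open, going by these compounds, is how 2-methyl-1H-imidazol-1-yl or 4-ethyl-1H-imidazol-1-yl would read, since either would separate the two changes. Also open, on these data alone, is whether the step holds with a carboxylic acid in place of the carboxamide.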